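This account rests on a few compounds, and the source may have more. Where it says the series, first, only, none or still open, it means among the compounds named here.

In an ADME assay on the whole organism (Mus musculus, strain CD1) for pharmacokinetics, read by LC-MS, with a stated time of 24 h, at a dose of 1 mg/kg by the intravenous route (on this read-out lower numbers stand for narrower distribution and higher numbers for wider distribution into tissues), compound 1 (`O=C(O)Cn1nc(Cc2nc3cc(Cl)c(OCC(F)F)cc3[nH]2)c2ccccc2c1=O`) gives 1.2 L/kg and compound 2 (`O=C(O)Cn1nc(Cn2cc3cc(OCC4CC4)c(Cl)cc3n2)c2ccccc2c1=O`) gives 0.69 L/kg while compound 3 (`O=C(O)Cc1nn(Cc2cn3cc(OCC4CC4)c(Cl)cc3n2)c2ccccc2c1=O`) gives 0.79 L/kg on the same scale. The number for compound 3 lies within the scatter of both compound 2 and compound 1, so no order can be read from these results.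

Compound 4 (`CCC(C(=O)O)c1nn(Cc2cn3cc(OCC4CC4)c(Cl)cc3n2)c2ccccc2c1=O`) differs from compound 3 by ethyl in place of hydrogen on a saturated chain carbon bound to an aromatic carbon and a carbonyl carbon in one place: ethyl in place of hydrogen on a saturated chain carbon bound to an aromatic carbon and a carbonyl carbon. The same difference reads as carboxymethyl to 1-carboxypropyl.

Going by the values given here, no measured pair differs in one place only, so no direct precedent for this change exists. The estimated step of a 1.1-fold higher number from compound 3 to compound 4 (0.03 log units; within the scatter) is expected to stay within the scatter, with no firm direction. That expectation rests on the number for compound 3 (0.79 L/kg) and on the structural change alone. For compound 4 the expected value is 0.85 L/kg with a range from 0.45 L/kg to 1.6 L/kg as the estimate.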

Compound 4, volume of distribution at steady state in the Mus musculus assay: 0.78 L/kg
Estimate against measurement, compound 4: 1.1-fold (0.04 log units) above; measured number inside the range.
By their numbers in the Mus musculus assay, from the lowest: compounds 2, 4, 3 and 1 (each within the scatter of the next).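

Going by these compounds alone, this is the first step that differs in one place only, and in the Mus musculus assay ethyl in place of hydrogen on a saturated chain carbon bound to an aromatic carbon and a carbonyl carbon gives a 1.0-fold lower number from compound 3 to compound 4 (0.01 log units; within the scatter) with no direction to read for distribution into tissues. Within the data shown here, in a physicochemical assay for solubility, measured as thermodynamic solubility, at pH 7.4 (on this read-out lower numbers stand for lower solubility and higher numbers for higher solubility), compound 3 gives 919 ug/mL and compound 4 gives 359 ug/mL, so the same ethyl lowers solubility beyond the scatter, a cost the earlier compounds could not show: the measured solubility of compound 3, 919 ug/mL, and of compound 4, 359 ug/mL, a 2.6-fold lower number (0.41 log units; beyond the scatter).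

Open, going by these compounds, is whether a methyl, a longer chain or a hydroxyl on this carbon would follow ethyl, with volume of distribution held and solubility lowered. Also open, on these data alone, is whether the same ethyl would behave alike on the core of compound 1 or on the core of compound 2.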